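Indane imidazoline series: pyrazolyl in place of pyridyl

A few compounds are considered here, and "the series" means these few. Any claim that something is new, unique, unknown or untested is made for them only; others in the source may bear on it.

Compound 1 `c1ccc(-c2cccc3c2CCC3c2ncc[nH]2)nc1` is tested in a functional assay on CHO cells for agonist activity at Alpha-1D adrenergic receptor (Homo sapiens), read by FLIPR and calcium flux; a higher number here means that more compound is needed for the effect, a lower number that less compound is needed. In this assay compound 1 gives only a limit, > 10000 nM, and no number. Compound 2 `COc1c(C)ccc2c1CCC2c1ncc[nH]1` is the other measured member of the series. In this assay compound 2 likewise gives only a limit, > 10000 nM. Among the measured compounds shown here, both readings sit at the limit of > 10000 nM in this assay, at which 2 of the 2 values shown sit, so compound 1 cannot be placed relative to compound 2 on the numbers, and no step between measured compounds exists. Compound 3 `c1cc(-c2ccn[nH]2)c2c(c1)C(c1ncc[nH]1)CC2` has not yet been measured. It differs from compound 1 by 1H-pyrazol-5-yl in place of pyridin-2-yl on an aromatic carbon; the entering group stands on an aromatic carbon of a six-membered aromatic ring of carbon only, part of a fused system of two rings, ortho to a fused ring and meta to a fused ring. With both measured compounds at the limit, nothing in the series calibrates this change. The step of an at least 1.1-fold lower number from compound 1 to compound 3 (0.04 log units; that floor lies within the scatter) is expected to be none beyond the scatter, with a limit the most probable outcome once more. Compound 3 is estimated at 9000 nM, within a range from 2000 nM to 30000 nM.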

Compound 3, half-maximal effective concentration: 336 nM
The estimate for compound 3 lay 27-fold (1.43 log units) above the measured number; measured number outside the range, below it.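

In this assay, 1H-pyrazol-5-yl in place of pyridin-2-yl on this aromatic carbon, ortho to a fused ring and meta to a fused ring, gives an at least 29-fold lower number from compound 1 to compound 3 (1.47 log units; beyond the scatter). The earlier compounds shown here could not show that this position responds at all, whereas this single change, with the rest of the core of compound 1 kept, moves the reading off the limit and into the measurable range, so the identity of the aromatic ring at this carbon matters for agonist activity at this receptor. Compound 1 gives > 10000 nM, which is a limit and not a number, so the size of the step is a floor and the true gap could be larger: the limit of > 10000 nM in this assay, at which 2 of the 3 values shown sit.

The change alters several things at once: ring size, the number of ring hetero atoms and the hydrogen-bond donor count, and this single pair cannot separate them. Going by these compounds, whether a methyl group on the pyrazole nitrogen, a thiazolyl ring or a furanyl ring at this carbon would keep the reading remains open, as does how the pyrazole compares at other receptors.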